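The source may hold more compounds than are shown below. What is called first, only, known or untested is meant among the compounds shown, and "the series" means these compounds.

Compound 1 `CCCCCc1cc(=O)c2cc([N+](=O)[O-])ccc2n1Cc1ccc(OC)cc1`: in an assay on isolated protein for inhibition of Intestinal-type alkaline phosphatase (Bos taurus), read by spectrophotometry, with stated times of 7 min and 15 min (a higher number here means a weaker inhibitor, a lower number a stronger inhibitor), compound 1 gives 1380 nM.
Compound 2 `COc1ccc(Cn2c(-c3ccc(C)cc3)c(Br)c(=O)c3cc([N+](=O)[O-])ccc32)cc1`: in this assay compound 2 gives 2430 nM.
Compound 3 `Cc1ccc(-c2c(Br)c(=O)c3cc([N+](=O)[O-])ccc3n2C(C)c2ccccc2)cc1`: in this assay compound 3 gives 2470 nM.

Compound 3 carries the highest of the three numbers, yet its gaps to compound 2 and to compound 1 both lie within the scatter, so none of the three can be set apart from the others. Compound 4 `Cc1ccc(-c2[nH]c3ccc([N+](=O)[O-])cc3c(=O)c2Br)cc1` is compound 3 with hydrogen in place of 1-phenylethyl on an aromatic nitrogen. Within the data shown here, the only measured step at this position is a 1.0-fold higher number from compound 2 to compound 3 (0.01 log units; within the scatter), which exchanged one group for another rather than removing it. Among the measured compounds shown here, no measured step strips the group away entirely, so the expectation rests on that one step and on how close all three numbers sit. In this assay compound 4 is expected to give about 2500 nM, between 800 nM and 8000 nM, an estimated step of a 1.0-fold higher number from compound 3 to compound 4 (0.01 log units; within the scatter) that should remain within the scatter.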

Compound 4, half-maximal inhibitory concentration: 12100 nM
Beside the measured number, compound 4's estimate is 4.8-fold (0.68 log units) below it, outside the stated range (above it).
By their numbers in this assay, from the lowest: compounds 1, 2 and 3 (each within the scatter of the next); then compound 4.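

In this assay, the group on the aromatic nitrogen does matter: swapping 4-methoxybenzyl for 1-phenylethyl left the number unchanged within the scatter, but replacing either with hydrogen gives a 4.9-fold higher number from compound 3 to compound 4 (0.69 log units; beyond the scatter) and a 5.0-fold higher number from compound 2 to compound 4 (0.70 log units; beyond the scatter) as the inhibitor weakens. Among these compounds, then, either group gives a stronger inhibitor than hydrogen, and the two cannot be told apart. Nothing available explains this loss. Still open, going by these compounds, is whether a small methyl group on that nitrogen would keep the stronger inhibition, or whether a longer chain ending in an amine or a carboxylic acid would do so.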